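The source may report more compounds than this note shows. Statements on the series, on what has been measured and on what is new or still open speak of the compounds shown alone.

Measured in an assay on cells for inhibition of Protein-serine O-palmitoleoyltransferase porcupine (Homo sapiens), read by reporter gene assay; on this read-out lower numbers stand for stronger inhibition and higher numbers for weaker inhibition:
Compound 1, `CN1C(=O)C2=C(C1=O)N(CC(=O)Nc1ccc(-c3ccncc3)cc1)CCC2`, gives 72 nM.
Compound 2, `CN1C(=O)C2=C(C1=O)N(CC(=O)Nc1ccc(-c3cccnc3)cc1)CCC2`, gives 8 nM.

Among the measured compounds shown here, compound 2 has the lowest number of the two measured compounds, and so the stronger inhibition in this assay; its only neighbour is compound 1, and the step between them is a 9.0-fold lower number from compound 1 to compound 2 (0.95 log units; beyond the scatter). Compound 3, `CN1C(=O)C2=C(C1=O)N(CC(=O)Nc1ccc(-c3ccccn3)cc1)CCC2`, has not yet been measured. It differs from compound 2 in one place: pyridin-2-yl in place of pyridin-3-yl on an aromatic carbon. For the measured compounds named here, the single measured step that bears on this, a 9.0-fold lower number from compound 1 to compound 2 (0.95 log units; beyond the scatter), also moved the ring nitrogen to a new position and was modest but beyond the scatter. A further move of the nitrogen may again shift the number beyond the scatter, but one step cannot fix the direction. The expected step is a 3.1-fold higher number from compound 2 to compound 3 (0.49 log units; beyond the scatter), a modest weakening. Compound 3 is therefore expected to give 25 nM, within a range from 6 nM to 100 nM.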

Compound 3, half-maximal inhibitory concentration: 67 nM
Compound 3: middle estimate off by 2.7-fold (0.43 log units), on the low side; the range from low to high includes it.
By their numbers in this assay, from the lowest: compound 2; then compounds 3 and 1 (each within the scatter of the next).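

In this assay, a step of an 8.4-fold higher number from compound 2 to compound 3 (0.92 log units; beyond the scatter) follows from moving the ring nitrogen to give pyridin-2-yl, so the low number of compound 2 belongs to pyridin-3-yl and not to any move of the nitrogen away from pyridin-4-yl. The other two placements cannot be told apart, with a step of a 1.1-fold lower number from compound 1 to compound 3 (0.03 log units; within the scatter) between them. Only the place of the nitrogen separates these three compounds, and nothing at hand explains why it matters.

Still open, as far as these compounds go, is whether a plain phenyl ring, a pyrimidine ring or a pyridin-3-yl ring carrying a methyl or an amine would match compound 2 at this position. Also open, from the compounds shown here alone, is whether pyridin-3-yl would hold its lead on a different core.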